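The source may report more compounds than this note shows. Statements on the series, on what has been measured and on what is new or still open speak of the compounds shown alone.

Measured in a functional assay on K562 cells (Homo sapiens) for inhibition, read by MTT assay, with a stated time of 48 h; on this read-out higher numbers stand for weaker inhibition and lower numbers for stronger inhibition:
compound 1, `CC(=O)Nc1n[nH]c2cc(-c3cn([C@@H]4CN[C@H](C(=O)Nc5ccc(Cl)c(C(F)(F)F)c5)C4)nn3)ccc12`, gives 15500 nM;
compound 2, `O=C(Nc1n[nH]c2cc(-c3cn([C@@H]4CN[C@H](C(=O)Nc5ccc(Cl)c(C(F)(F)F)c5)C4)nn3)ccc12)C1CC1`, gives 5200 nM;
compound 3, `CC(=O)Nc1nc2ccc(-c3cn([C@@H]4CN[C@H](C(=O)Nc5ccc(Cl)cc5Cl)C4)nn3)nc2s1`, gives 9670 nM.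

Compound 2 differs from compound 1 by cyclopropyl in place of methyl on a carbonyl carbon, and this change gave a 3.0-fold lower number from compound 1 to compound 2 (0.47 log units; beyond the scatter). Compound 3 carries a different core; the difference between the two cores is not broken down here, and its value lies within the scatter of compound 1. Compound 4, `O=C(Nc1nc2ccc(-c3cn([C@@H]4CN[C@H](C(=O)Nc5ccc(Cl)cc5Cl)C4)nn3)nc2s1)C1CC1`, has not been measured; it differs from compound 3 by cyclopropyl in place of methyl on a carbonyl carbon, the same change at the same place. Because a 3.0-fold lower number from compound 1 to compound 2 (0.47 log units; beyond the scatter) was modest but beyond the scatter, a step of similar size is expected from compound 3 to compound 4, namely a 2.8-fold lower number from compound 3 to compound 4 (0.44 log units; beyond the scatter). On that basis compound 4 is estimated at 3500 nM, expected to fall between 1500 nM and 8000 nM.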

Compound 4, half-maximal inhibitory concentration: 740 nM
For compound 4 the middle estimate is 4.7-fold (0.67 log units) above the measured one; the whole stated range lies above it.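

In this assay, cyclopropyl in place of methyl on a carbonyl carbon gave a 13-fold lower number from compound 3 to compound 4 (1.12 log units; beyond the scatter). The direction of the change carried over from one core to the other, but its size did not: the same change on two cores in this assay, a 3.0-fold lower number (0.47 log units; beyond the scatter) from compound 1 to compound 2 and a 13-fold lower number (1.12 log units; beyond the scatter) from compound 3 to compound 4, 4.4-fold (0.64 log units) apart, beyond the scatter of two such steps. The two pairs differ from each other in more than one place, so these data do not show which difference goes with the larger step, and two pairs set no rule for any further core.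

The compounds shown leave open how an ethyl, an isopropyl or a cyclobutyl on the same carbonyl carbon would compare with methyl and cyclopropyl. They also leave open whether either step would hold on a third core.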